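The source may hold more compounds than are shown below. What is called first, only, known or untested is meant among the compounds shown, and "the series" means these compounds.

In an ADME assay on HepG2 cells (Homo sapiens) for cytotoxicity, read by MTT assay, with a stated time of 72 h (a lower number here means that less compound is tolerated, a higher number that more compound is tolerated), three compounds sharing one core have numbers: compound 1 `CCCCNc1nc2cc(-c3ccc(C)cc3)sc2c(=O)[nH]1` gives 6000 nM, compound 2 `CCCCCCCNc1nc2cc(-c3ccc(C)cc3)sc2c(=O)[nH]1` gives 6800 nM and compound 3 `Cc1ccc(-c2cc3nc(NC(C)c4ccccc4)[nH]c(=O)c3s2)cc1` gives 9200 nM. Compound 3 cannot be told apart from the other two, as its gaps to both lie within the scatter. Compound 4 `Cc1ccc(-c2cc3nc(NCc4ccccc4Cl)[nH]c(=O)c3s2)cc1` differs from compound 3 by one swap: 2-chlorobenzyl in place of 1-phenylethyl on a nitrogen on an aromatic ring. Three measured steps changed the group on this same nitrogen: a 1.1-fold higher number from compound 1 to compound 2 (0.05 log units; within the scatter), a 1.5-fold higher number from compound 1 to compound 3 (0.19 log units; within the scatter) and a 1.4-fold higher number from compound 2 to compound 3 (0.13 log units; within the scatter). Going by the values given here, all stayed within the scatter, though no measured compound carries chlorine. The expected step is therefore small, a 1.2-fold lower number from compound 3 to compound 4 (0.06 log units; within the scatter), and none beyond the scatter is anticipated. Compound 4 is estimated at 8000 nM, with an expected range of 3500 nM to 16000 nM.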

Compound 4, half-maximal cytotoxic concentration: 32600 nM
Beside the measured number, compound 4's estimate is 4.1-fold (0.61 log units) below it; measured number above the stated range.
By their numbers in this assay, from the lowest: compounds 1, 2 and 3 (each within the scatter of the next); then compound 4.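

Going by these compounds alone, this nitrogen tolerates more change than the earlier compounds suggested: in this assay, 2-chlorobenzyl in place of 1-phenylethyl gives a 3.5-fold higher number from compound 3 to compound 4 (0.55 log units; beyond the scatter), the first step here beyond the scatter. The same group also stands clear of the straight chains, with a 4.8-fold higher number from compound 2 to compound 4 (0.68 log units; beyond the scatter) and a 5.4-fold higher number from compound 1 to compound 4 (0.74 log units; beyond the scatter). No measurement shown here explains this rise.

On these data alone, whether the chlorine or the loss of the methyl branch carries the step stays open, and plain benzyl would separate the two. As far as these compounds go, how a chain ending in an amine or a carboxylic acid would behave on this nitrogen also stays open.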